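The compounds below may be only part of what the source reports. "The series", "measured", "known", "first", "only" and "open" are said of these compounds alone.

Values in a functional assay on KB cells (Homo sapiens) for inhibition, read by sulforhodamine B assay, with a stated time of 48 h; a higher number here means a weaker inhibitor of growth, a lower number a stronger inhibitor of growth:

- Compound 1 `COc1ccc2c(c1)NC(=O)CN2c1nc(OCC2CC2)nc2ccccc12`: 14.2 nM
- Compound 2 `COc1ccc2c(c1)NC(=O)CN2c1nc(NC2CC2)nc2ccccc12`: 2.11 nM
- Compound 3 `COc1ccc2c(c1)NC(=O)CN2c1nc(NCc2ccncc2)nc2ccccc12`: 7.5 nM

Compound 1 stands at the high end of these numbers, but not alone: the data show a 1.9-fold lower number from compound 1 to compound 3 (0.28 log units; within the scatter), and also a 6.7-fold lower number from compound 1 to compound 2 (0.83 log units; beyond the scatter). Compound 4 `COc1ccc2c(c1)NC(=O)CN2c1nc(NC2CCCC2)nc2ccccc12` keeps the core of compound 1 and changes in one place, on an aromatic carbon between two ring nitrogen atoms: cyclopentylamino in place of cyclopropylmethoxy on an aromatic carbon. No cyclopentylamino compound has been measured yet, so the closest guides are the two steps that also replace cyclopropylmethoxy with an amino group, shown above. One is modest and the other stays within the scatter, and both point towards a lower number. The group carried on that nitrogen also matters, as a 3.6-fold higher number from compound 2 to compound 3 (0.55 log units; beyond the scatter) shows. A modest step towards a lower number is therefore expected, though it may not clear the scatter. The expected change is a 2.8-fold lower number from compound 1 to compound 4 (0.45 log units; beyond the scatter). For compound 4 the estimated value is 5 nM, with an expected range from 1.5 nM to 15 nM.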

Compound 4, concentration for 50% growth inhibition: 6.92 nM
Beside the measured number, compound 4's estimate is 1.4-fold (0.14 log units) below it; the range from low to high includes it.
By their numbers in this assay, from the lowest: compound 2; then compounds 4, 3 and 1 (each within the scatter of the next, the first and the last beyond it).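

At this carbon between two ring nitrogen atoms, cyclopentylamino in place of cyclopropylmethoxy lowers the number in this assay just beyond the scatter (a 2.1-fold lower number from compound 1 to compound 4 (0.31 log units; beyond the scatter)). This adds a second amino group that clearly improves on compound 1, while compound 3 stays within the scatter of compound 1. The carbon ring on the nitrogen also matters, as cyclopentyl in place of cyclopropyl raises the number (a 3.3-fold higher number from compound 2 to compound 4 (0.52 log units; beyond the scatter)), whereas cyclopentyl and (pyridin-4-yl)methyl cannot be told apart (a 1.1-fold lower number from compound 3 to compound 4 (0.03 log units; within the scatter)).

From the compounds shown here alone, whether a cyclobutyl ring, an ethyl chain or an unsubstituted amine on this carbon would match compound 2 remains open. No measurement here explains why the amino compounds differ from one another.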